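This account rests on a few compounds, and the source may have more. Where it says the series, first, only, none or still open, it means among the compounds named here.

Measured compounds in a functional assay on CCRF-CEM cells (Homo sapiens); a lower number here means that less compound is tolerated, a higher number that more compound is tolerated:
Compound 1, `CCOC(=O)NC(=O)NC1=CS(=O)(=O)O[C@@]12[C@@H](CO[Si](C)(C)C(C)(C)C)O[C@@H](n1cc(C)c(=O)n(C)c1=O)[C@@H]2O[Si](C)(C)C(C)(C)C`: compound 1 gives 3000 nM.
Compound 2, `Cc1cn([C@@H]2O[C@H](CO[Si](C)(C)C(C)(C)C)[C@@]3(OS(=O)(=O)C=C3NCCC(=O)OCc3ccccc3)[C@H]2O[Si](C)(C)C(C)(C)C)c(=O)n(C)c1=O`: compound 2 gives > 250000 nM, which is a limit of the assay and not a number.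
Compound 3, `CCOC(=O)CNC(=O)NC1=CS(=O)(=O)O[C@@]12[C@@H](CO[Si](C)(C)C(C)(C)C)O[C@@H](n1cc(C)c(=O)n(C)c1=O)[C@@H]2O[Si](C)(C)C(C)(C)C`: compound 3 gives 5020 nM.

Compound 2 therefore stands at the top of what this assay can report, at the limit of > 250000 nM in this assay, at which 1 of the 3 values shown sits, while compound 1 and compound 3 sit at numbers well inside the measurable range. The unmeasured compound 4, `Cc1cn([C@@H]2O[C@H](CO[Si](C)(C)C(C)(C)C)[C@@]3(OS(=O)(=O)C=C3NCC(=O)C(=O)O)[C@H]2O[Si](C)(C)C(C)(C)C)c(=O)n(C)c1=O`, differs from compound 2 in one place: carboxycarbonyl in place of (benzyloxycarbonyl)methyl on a saturated chain carbon bound to an amine nitrogen.

The measured steps that touch the same amine nitrogen are an at least 83-fold higher number from compound 1 to compound 2 (1.92 log units; beyond the scatter) and an at least 49-fold lower number from compound 2 to compound 3 (1.69 log units; beyond the scatter). Both show that exchanging the 2-(benzyloxycarbonyl)ethyl chain for a carbamoyl-type group moves the number far lower, beyond the scatter. Within the data shown here, the change to compound 4 keeps a chain on the amine nitrogen but removes the ring and brings in a carboxycarbonyl group, for which no measured step exists. The expectation for compound 4 is therefore uncertain, with a lowered number possible but a limit also plausible; the estimated step is an at least 2.0-fold lower number from compound 2 to compound 4 (0.31 log units; beyond the scatter). Compound 4 is estimated at 120000 nM, ranging from 15000 nM to 300000 nM.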

Compound 4, half-maximal cytotoxic concentration: 72600 nM
The estimate for compound 4 lay 1.7-fold (0.22 log units) above the measured number, within the range that was stated.
By their numbers in this assay, from the lowest: compounds 1 and 3 (each within the scatter of the next); then compound 4. At a limit, above all of these: compound 2.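

In this assay, putting carboxycarbonyl in place of (benzyloxycarbonyl)methyl on a saturated chain carbon bound to an amine nitrogen gives an at least 3.4-fold lower number from compound 2 to compound 4 (0.53 log units; beyond the scatter), so a chain on this nitrogen does not by itself keep a compound out of the measurable range. The true size of that step stays open on one side, since compound 2 is held at a limit and not a number: the limit of > 250000 nM in this assay, at which 1 of the 4 values shown sits.

The gap between chain and carbamoyl-type groups on this nitrogen now rests on a real number, with a 14-fold higher number from compound 3 to compound 4 (1.16 log units; beyond the scatter) and a 24-fold higher number from compound 1 to compound 4 (1.38 log units; beyond the scatter).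

The compounds shown do not separate the loss of the six-membered aromatic ring from the arrival of the carboxycarbonyl group, since both happen in one change. A simple carboxylic acid on the same chain, or a benzyl ester on a shorter chain, would pull these two apart.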